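This account rests on a few compounds, and the source may have more. Where it says the series, first, only, none or still open, it means among the compounds named here.

Three compounds with a shared core, differing in one group, have numbers in a toxicity assay on MT4 cells (Homo sapiens) for cytotoxicity, read by MTT assay, with a stated time of 5 days; a higher number here means that more compound is tolerated, a lower number that less compound is tolerated. Compound 1 `Cc1cnc(Nc2ccc(C#N)cc2)nc1Nc1c(F)cc(-c2cccnc2)cc1F`, with pyridin-3-yl, gives 1100 nM, and compound 2 `Cc1cnc(Nc2ccc(C#N)cc2)nc1Nc1c(F)cc(-c2cncnc2)cc1F`, with pyrimidin-5-yl, gives 900 nM. Compound 3 `Cc1cnc(Nc2ccc(C#N)cc2)nc1Nc1c(F)cc(-c2ccnc(F)c2)cc1F`, with 2-fluoropyridin-4-yl, gives 167000 nM, the highest of the three numbers. In compound 4 `Cc1cnc(Nc2ccc(C#N)cc2)nc1Nc1c(F)cc(-c2cncc(C#N)c2)cc1F`, 5-cyanopyridin-3-yl takes the place of 2-fluoropyridin-4-yl on an aromatic carbon: 5-cyanopyridin-3-yl in place of 2-fluoropyridin-4-yl on an aromatic carbon.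

For the measured compounds named here, three measured steps bear on this change. Exchanging pyridin-3-yl for pyrimidin-5-yl gave a 1.2-fold lower number from compound 1 to compound 2 (0.09 log units; within the scatter). Moving to 2-fluoropyridin-4-yl gave a 150-fold higher number from compound 1 to compound 3 (2.18 log units; beyond the scatter) and a 190-fold higher number from compound 2 to compound 3 (2.27 log units; beyond the scatter), both large. The group in compound 4 is named as a pyridin-3-yl carrying a cyano group, so it reads closer to the group of compound 1, at 1100 nM, than to that of compound 3. Going by the values given here, no measured compound carries that cyano group, so the expectation stays wide. A large step towards a lower number is expected, estimated as a 42-fold lower number from compound 3 to compound 4 (1.62 log units; beyond the scatter). For compound 4 the estimated value is 4000 nM, with an expected range from 600 nM to 60000 nM.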

Compound 4, half-maximal cytotoxic concentration: 50000 nM
Compound 4: the middle estimate sits 13-fold (1.10 log units) below what was measured, and the stated range covers the measured number.
By their numbers in this assay, from the lowest: compounds 2 and 1 (each within the scatter of the next); then compound 4; then compound 3.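

In this assay, adding a cyano group to the pyridin-3-yl ring of compound 1 gives a 45-fold higher number from compound 1 to compound 4 (1.66 log units; beyond the scatter) and shows that a high number does not depend on the 2-fluoropyridin-4-yl group of compound 3. Compared with the unsubstituted pyrimidin-5-yl ring, 5-cyanopyridin-3-yl gives a 56-fold higher number from compound 2 to compound 4 (1.74 log units; beyond the scatter). Its distance from the other substituted ring is much smaller, with a 3.3-fold lower number from compound 3 to compound 4 (0.52 log units; beyond the scatter) still beyond the scatter, so among these four compounds the two rings carrying a further group have the highest numbers.

On these data alone, whether other groups on the pyridin-3-yl ring, such as an amine or a methoxy group, would raise the number as the cyano group does remains open. The data shown also offer no measurement that explains why this cyano group raises the number so much.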